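Putting a benzyl group back on compound 2

The source may report more compounds than this note shows. Statements on the series, on what has been measured and on what is new or still open speak of the compounds shown alone.

- compound 1 `Cc1cc(C)cc(Cn2c(=O)cc(C)n(C3C=CC(OC(=O)c4ccccc4)C3)c2=O)c1`: 25000 nM
- compound 2 `Cc1cc(=O)[nH]c(=O)n1C1C=CC(OC(=O)c2ccccc2)C1`: > 250000 nM, a limit and not a number

Both entries come from an ADME assay on CCRF-CEM cells (Homo sapiens) for cytotoxicity, with a stated time of 3 days; on this read-out lower numbers stand for higher toxicity in this test and higher numbers for lower toxicity in this test. Compound 2 gives > 250000 nM, which is a limit of the assay and not a number. Compound 2 therefore stands at the limit of > 250000 nM in this assay, at which 1 of the 2 values shown sits.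

Compound 3 `Cc1ccc(Cn2c(=O)cc(C)n(C3C=CC(OC(=O)c4ccccc4)C3)c2=O)cc1` has 4-methylbenzyl in place of hydrogen on an aromatic nitrogen of compound 2 (4-methylbenzyl in place of hydrogen on an aromatic nitrogen).

Going by the values given here, one measured step bears on this change: an at least 10-fold higher number from compound 1 to compound 2 (1.00 log units; beyond the scatter), with hydrogen in place of 3,5-dimethylbenzyl on an aromatic nitrogen. Compound 3 runs this exchange the other way, with a related benzyl group entering. A move of similar size towards a lower number in this assay is therefore expected, meaning higher toxicity in this test. Among the compounds with values here, with only one such step, the size remains uncertain. The closest reference is compound 1 at 25000 nM.

The expected change is an at least 8.3-fold lower number from compound 2 to compound 3 (0.92 log units; beyond the scatter). For compound 3 the estimated value is 30000 nM, with an expected range of 10000 nM to 120000 nM.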

Compound 3, half-maximal cytotoxic concentration: 20000 nM
The estimate for compound 3 lay 1.5-fold (0.18 log units) above the measured number, and the stated range covers the measured number.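

This is the second benzyl group on this ring nitrogen to move the read-out the same way, so the earlier step no longer stands alone: in this assay the change gives an at least 12-fold lower number from compound 2 to compound 3 (1.09 log units; beyond the scatter). On these data alone, compound 2 carries a limit of the assay and not a number, so the full size of this step stays unknown: the limit of > 250000 nM in this assay, at which 1 of the 3 values shown sits. The two benzyl compounds themselves cannot be told apart, as swapping 3,5-dimethylphenyl for 4-methylphenyl gives a 1.3-fold lower number from compound 1 to compound 3 (0.10 log units; within the scatter), so among these three compounds the presence of a methyl-bearing benzyl group on the nitrogen matters, while the difference between these two methyl patterns does not show.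

Every group shown on this nitrogen is a hydrogen or a benzyl carrying methyl groups, so it stays open whether a plain benzyl, a simple butyl chain or a benzyl bearing an amine or a carboxylic acid would shift the number as far. As far as these compounds go, it also stays open whether the aromatic ring is needed at all, or whether a cyclohexylmethyl group, which has a ring of saturated carbon instead, would serve equally well.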